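A few compounds are considered here, and "the series" means these few. Any claim that something is new, unique, unknown or untested is made for them only; others in the source may bear on it.

Measured so far:
- compound 1 `Oc1cccc(-c2cc(-c3ccccc3C(F)(F)F)cc(-c3ccccc3O)n2)c1`: 9010 nM
- compound 2 `Oc1ccccc1-c1cc(-c2ccccc2OC(F)(F)F)cc(-c2ccccc2O)n1`: 4520 nM

In a functional assay on HCT-15 cells (Homo sapiens) for inhibition (on this read-out lower numbers stand for stronger inhibition and higher numbers for weaker inhibition), compound 1 gives 9010 nM, and compound 2 gives 4520 nM. Compound 2 has the lower of the two numbers, but compound 1 sits only a step within the usual scatter from it, so the two cannot be told apart on these data. The two compounds differ in more than one place, so no single-change step can be read from them.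

Compound 3 `Oc1cccc(-c2cc(-c3ccccc3OC(F)(F)F)cc(-c3ccccc3O)n2)c1` is not yet measured. It differs from compound 2 by 3-hydroxyphenyl in place of 2-hydroxyphenyl on an aromatic carbon. Among the compounds with values here, since no measured pair isolates this change, its effect is unknown; with only two measured compounds, and those within scatter of each other, no trend can be drawn. The expectation is that the step from compound 2 to compound 3 a 1.3-fold higher number from compound 2 to compound 3 (0.12 log units; within the scatter) stays within the scatter, with no clear direction. Compound 3 is estimated at 6000 nM, with a range of 2000 nM to 18000 nM.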

Compound 3, half-maximal inhibitory concentration: 3240 nM
Compound 3: the middle estimate sits 1.9-fold (0.27 log units) above what was measured; the measured number falls inside the stated range.
By their numbers in this assay, from the lowest: compounds 3, 2 and 1 (each within the scatter of the next, the first and the last beyond it).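

In this assay, at the aromatic carbon next to the ring nitrogen, 3-hydroxyphenyl in place of 2-hydroxyphenyl gives a 1.4-fold lower number from compound 2 to compound 3 (0.14 log units; within the scatter) and so cannot be told from no change; on these values, this position tolerates either hydroxyphenyl. Trifluoromethoxy in place of trifluoromethyl on an aromatic carbon gives a 2.8-fold lower number from compound 1 to compound 3 (0.44 log units; beyond the scatter) as the first single-change step in the series that stands beyond the scatter, though it is modest. No supporting data bear on why either step has this size.

The compounds shown leave open how an aminophenyl or a methoxyphenyl would read at the position next to the ring nitrogen. Also open, from the compounds shown here alone, is whether the exchange of trifluoromethyl for trifluoromethoxy carries over with 2-hydroxyphenyl at that position, and how a chlorine or a longer ether chain would read in its place.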